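This account rests on a few compounds, and the source may have more. Where it says the series, first, only, none or still open, it means among the compounds named here.

Compound 2 `O=c1c(Cl)c(-c2cnn(Cc3ccc(OC(F)(F)F)cc3)c2)[nH]c2ccccc12` gives 10 nM in a physicochemical assay for solubility, in phosphate buffer, at pH 7.4 (on this read-out higher numbers stand for higher solubility and lower numbers for lower solubility), the lowest of the two numbers in hand. Going by the values given here, compound 1 `Cc1c(-c2cnn(Cc3ccc(OC(F)(F)F)cc3)c2)[nH]c2ccccc2c1=O` gives 100 nM in the same assay, and the only measured step, a 10-fold lower number from compound 1 to compound 2 (1.00 log units; beyond the scatter), is modest but beyond the scatter. Compound 3 `CCc1c(-c2cnn(Cc3ccc(OC(F)(F)F)cc3)c2)[nH]c2ccccc2c1=O` differs from compound 2 by ethyl in place of chloro on an aromatic carbon, which undoes the chloro of that step and puts in an alkyl group larger than the methyl of compound 1, so a rise of similar size is expected, with a 5.0-fold higher number from compound 2 to compound 3 (0.70 log units; beyond the scatter) as the estimated step. Compound 3 is expected at 50 nM, within 12 nM to 200 nM.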

Compound 3, solubility: 200 nM
Estimate against measurement, compound 3: 4.0-fold (0.60 log units) below; measured number inside the range.
By their numbers in this assay, from the lowest: compound 2; then compounds 1 and 3 (each within the scatter of the next).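

In this assay, ethyl in place of chloro on this aromatic carbon gives a 20-fold higher number from compound 2 to compound 3 (1.30 log units; beyond the scatter) and sets the chloro of compound 2 apart from both alkyl groups. Lengthening methyl to ethyl gives a 2.0-fold higher number from compound 1 to compound 3 (0.30 log units; within the scatter) and so separates the two alkyl groups by no more than the scatter. Nothing available explains the gap between chloro and the alkyl groups.

Still open, from the compounds shown here alone, is whether fluoro or bromo would read like chloro at this position. Also open, going by these compounds, is where a longer chain, a methoxy group or an amine would fall.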